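Swapping the Anilino Group on a Weakly Active Quinazoline

The source may hold more compounds than are shown below. What is called first, only, known or untested is meant among the compounds shown, and "the series" means these compounds.

Compound 2 `O=[N+]([O-])c1cccc(Nc2ncnc3ccc(OCc4cn(-c5ccccc5[N+](=O)[O-])nn4)cc23)c1` was examined in a functional assay on HepG2 cells (Homo sapiens) for cytotoxicity, read by MTT assay; a lower number here means a stronger inhibitor, a higher number a weaker inhibitor. In this assay compound 2 gave only > 200000 nM, which is a limit of the assay and not a measured number. Compound 1 `C#CCOc1ccc2ncnc(N3CCN(C)CC3)c2c1` in this assay likewise reached only the limit > 200000 nM. Both share (the limit of > 200000 nM in this assay, at which 2 of the 2 values shown sit). Compound 3 `CN1CCN(c2ncnc3ccc(OCc4cn(-c5ccccc5[N+](=O)[O-])nn4)cc23)CC1` arises from compound 2 through the change (4-methylpiperazin-1-yl in place of (3-nitrophenyl)amino on an aromatic carbon). Within the data shown here, no measured step links these two compounds, so the expected step is a step that the limit leaves unreadable from compound 2 to compound 3, no change beyond the scatter. Compound 3 is therefore estimated at 300000 nM, with a range from 100000 nM to 1000000 nM, most likely reported again as a limit.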

Compound 3, half-maximal inhibitory concentration: 143000 nM
Compound 3: the middle estimate sits 2.1-fold (0.32 log units) above what was measured; the measured number falls inside the stated range.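

In this assay, 4-methylpiperazin-1-yl on this aromatic carbon gives a measured number, which (3-nitrophenyl)amino on the same core did not. The change reads as an at least 1.3-fold lower number from compound 2 to compound 3 (0.14 log units; that floor lies within the scatter), so it cannot be called a real gain in strength. Most of what is shown remains a limit of the assay and not a number: the limit of > 200000 nM in this assay, at which 2 of the 3 values shown sit.

Still open, going by these compounds, is whether another group on this carbon, such as morpholine or a simple primary amine, would lower the number beyond the scatter. The compounds shown cannot settle that.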